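A few compounds are considered here, and "the series" means these few. Any claim that something is new, unique, unknown or untested is made for them only; others in the source may bear on it.

Working notes on the series in an assay on isolated protein for displacement of a labelled ligand from metabotropic glutamate receptor 5 (Homo sapiens), with a stated time of 60 min, tested at 1 uM; on this read-out higher numbers stand for more inhibition at the one concentration tested (going by the name of the read-out) and lower numbers for less inhibition. Compound 1 `COc1ccc(S(=O)(=O)c2cnc3ccc(C)cc3c2N2CCC(C)CC2)cc1` gives 62%. Compound 2 `CC1CCN(c2c(S(=O)(=O)c3ccc(Cl)cc3)cnc3c(F)cccc23)CC1` gives 85%, the highest of the three numbers measured, though compound 3 `CC1CCN(c2c(S(=O)(=O)c3ccc(Cl)cc3)cnc3ccc(F)cc23)CC1`, with 80%, lies within the scatter of it, while the gap to compound 1 is beyond the scatter. Among the measured compounds shown here, no pair among the measured compounds differs in one place only, so no single step has been characterised.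

Compound 4 `CC1CCN(c2c(S(=O)(=O)c3ccc(F)c(Cl)c3)cnc3c(F)cccc23)CC1` is not yet measured. 3-chloro-4-fluorophenyl in place of 4-chlorophenyl on a sulfonyl sulfur is the whole of the change from compound 2. With nothing in the measured set speaking to this change, any step is expected to be small, likely within the scatter, in no firm direction. Compound 4 is estimated at 82%, with a range of 65% to 95%, which as a step from compound 2 means an expected a number 3 percentage points lower from compound 2 to compound 4 (within the scatter).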

Compound 4, a percentage reported as inhibition, at one concentration (the size of the read-out at that concentration, not a potency): 95%
Compound 4: middle estimate off by 13 percentage points, on the low side; measured number inside the range.
By their numbers in this assay, from the lowest: compound 1; then compounds 3, 2 and 4 (each within the scatter of the next, the first and the last beyond it).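

In this assay, the series now has its first characterised single-place step: on a sulfonyl sulfur, 3-chloro-4-fluorophenyl in place of 4-chlorophenyl gives a number 10 percentage points higher from compound 2 to compound 4 (within the scatter). This place therefore accepts the larger of these two halogenated phenyl groups with no change beyond the scatter. Nothing available explains the size of this step.

As far as these compounds go, whether 3-chlorophenyl alone would read like 3-chloro-4-fluorophenyl remains open. So does the outcome at this place with a group other than a substituted phenyl, such as a pyridine ring or an n-butyl chain.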